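The source may report more compounds than this note shows. Statements on the series, on what has been measured and on what is new or still open speak of the compounds shown alone.

Of the compounds shown here, three of one series have been measured in a functional assay on NCI-H226 cells (Homo sapiens) for inhibition, read by MTT assay, with a stated time of 48 h, tested at 10 uM; a lower number here means less inhibition, a higher number more inhibition at the concentration tested (going by the name of the read-out). Compound 1 `COc1ccc(F)cc1Nc1cc(NC(=O)Nc2c(Cl)cccc2Cl)ncn1` gives 31.3%. Compound 2 `COc1cc(NC(=O)Nc2cc(Nc3cccc(C(C)(C)C)c3)ncn2)cc(OC)c1` gives 40%, and compound 3 `COc1cc(NC(=O)Nc2cc(Nc3cc(F)ccc3OC)ncn2)cc(OC)c1` gives 37.7%. Compound 1 has the lowest of the three numbers, yet its distances to the others are small: the change of the group on the amide-type nitrogen gave a number 6.4 percentage points higher from compound 1 to compound 3 (within the scatter), and compound 2 sits only a little above compound 3.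

Compound 4 `COc1cc(Br)ccc1Nc1cc(NC(=O)Nc2c(Cl)cccc2Cl)ncn1` has not yet been measured in this assay. It differs from compound 1 in one place: 4-bromo-2-methoxyphenyl in place of 5-fluoro-2-methoxyphenyl on a nitrogen on an aromatic ring. The measured step that bears most directly on this change is the one at the same nitrogen, a number 2.3 percentage points lower from compound 2 to compound 3 (within the scatter), which exchanged one aryl group for another without moving beyond the scatter. The other step in the series, at the amide-type nitrogen, likewise stayed within the scatter. Among the measured compounds shown here, nothing among the measured compounds suggests that swapping one substituted phenyl for another at this nitrogen shifts the inhibition much, so compound 4 is expected to land close to compound 1, with an expected step of a number 2.7 percentage points higher from compound 1 to compound 4 (within the scatter). Compound 4 is therefore estimated at 34%, with a likely range from 20% to 48%.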

Compound 4, a percentage reported as inhibition, at one concentration (the size of the read-out at that concentration, not a potency): 43%
Compound 4: middle estimate off by 9 percentage points, on the low side; the measured number falls inside the stated range.
By their numbers in this assay, from the lowest: compounds 1, 3, 2 and 4 (each within the scatter of the next, the first and the last beyond it).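

In this assay, replacing 5-fluoro-2-methoxyphenyl with 4-bromo-2-methoxyphenyl on the nitrogen on an aromatic ring gave a number 11.7 percentage points higher from compound 1 to compound 4 (beyond the scatter), the only step shown so far that lies beyond the scatter. The aryl group at this nitrogen can therefore matter, which the earlier exchange at the same place, a number 2.3 percentage points lower from compound 2 to compound 3 (within the scatter), did not reveal, although that exchange involved different groups and a different partner on the amide-type nitrogen. Both groups in the new step keep the methoxy group and have the same heavy-atom count, yet the halogen and its printed position both differ, and no available evidence explains the change.

The compounds shown leave open whether the step follows from bromine replacing fluorine, from the different ring position, or from both together. They also leave open whether the step would persist with 3,5-dimethoxyphenyl on the amide-type nitrogen, and how an amine or a carboxylic acid in place of the bromine would read in this assay.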